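The source may report more compounds than this note shows. Statements on the series, on what has been measured and on what is new or still open speak of the compounds shown alone.

Measured compounds:
Compound 1, `O=C(NCc1cc(Cl)ccc1-n1cnnn1)[C@@H]1[C@@H]2C[C@@H]2CN1C(=O)[C@H](O)c1ccccc1F`, in an ADME assay on liver for metabolic stability, with Liver microsome (Homo sapiens) as the target, read by LC-MS, using microsomes; on this read-out higher numbers stand for fast clearance and lower numbers for slow clearance: < 12 mL.min-1.g-1
Compound 2, `O=C(NCc1cc(Cl)ccc1-n1cnnn1)[C@@H]1C[C@@H]2C[C@@H]2N1C(=O)[C@H](O)c1ccccc1F`: < 12 mL.min-1.g-1
Compound 3, `O=C(NCc1cc(Cl)ccc1-n1cnnn1)[C@@H]1[C@@H]2C[C@@H]2CN1C(=O)[C@H](O)c1ccccc1`: < 15 mL.min-1.g-1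

Each of these values is a limit of the assay and not a number. Compound 1 sits at a limit with < 12 mL.min-1.g-1. Compound 2 sits at the same limit with < 12 mL.min-1.g-1. Compound 3 sits at a limit with < 15 mL.min-1.g-1. Compounds 1 and 2 have the same atoms joined differently; the difference between the two cores is not broken down here. From compound 1 to compound 3 the change is hydrogen in place of fluoro on an aromatic carbon, and the step is a step that the two limits leave unreadable from compound 1 to compound 3. The same change, (hydrogen in place of fluoro on an aromatic carbon), carries compound 2 to compound 4, `O=C(NCc1cc(Cl)ccc1-n1cnnn1)[C@@H]1C[C@@H]2C[C@@H]2N1C(=O)[C@H](O)c1ccccc1`, which has not been measured in this assay. The step from compound 2 to compound 4 is expected to be a step that the limit leaves unreadable from compound 2 to compound 4, resting on a step that the two limits leave unreadable from compound 1 to compound 3. Compound 4 is estimated at 8 mL.min-1.g-1, between 3 mL.min-1.g-1 and 16 mL.min-1.g-1.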

Compound 4, intrinsic clearance in microsomes: < 16 mL.min-1.g-1
Compound 4: no number, only a limit (the forecaster's own chance of this, stated with the estimate: 85%); the middle value lies beyond the limit too.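

In this assay compound 4 gives < 16 mL.min-1.g-1, a limit and not a number. Compound 2 gives < 12 mL.min-1.g-1, also a limit. Within the data shown here, no step can therefore be read between compound 2 and compound 4. The compounds shown leave open what size, if any, the change from 2-fluorophenyl to phenyl has on clearance.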